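Swapping a methylurea for a sulfamide on a shared core

The source may hold more compounds than are shown below. What is called first, only, known or untested is meant among the compounds shown, and "the series" means these compounds.

Three compounds share one core and differ only in the group on a saturated chain carbon bound to a saturated ring carbon. In an assay on isolated protein for displacement of a labelled ligand from 5-hydroxytryptamine receptor 6 (Homo sapiens) (on this read-out lower numbers stand for stronger inhibition and higher numbers for weaker inhibition), compound 1 `O=S(=O)(c1cccc(F)c1)c1ccc2c(c1)CCC[C@H]2CN1CCCS1(=O)=O` gives 31.6 nM. Compound 2 `O=C1CN=C(NC[C@@H]2CCCc3cc(S(=O)(=O)c4cccc(F)c4)ccc32)N1` gives 0.1 nM, and compound 3 `CN(C[C@@H]1CCCc2cc(S(=O)(=O)c3cccc(F)c3)ccc21)C(N)=O` gives 39.8 nM. Of the three numbers, compound 3 has the highest; the nearest is compound 1, and the two are within the scatter of each other, while compound 2 stands far apart, as the step of a 400-fold higher number from compound 2 to compound 3 (2.60 log units; beyond the scatter) shows.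

Compound 4 `NS(=O)(=O)NC[C@@H]1CCCc2cc(S(=O)(=O)c3cccc(F)c3)ccc21` carries the change (sulfamoylamino in place of carbamoyl(methyl)amino on a saturated chain carbon bound to a saturated ring carbon). For the measured compounds named here, two measured steps bear on this. The step of a 1.3-fold higher number from compound 1 to compound 3 (0.10 log units; within the scatter) shows that trading a ring-bound sulfonamide for an open methylurea left the number essentially unchanged. The step of a 320-fold lower number from compound 1 to compound 2 (2.50 log units; beyond the scatter) shows that a very different group, a five-membered ring with three nitrogens, can lower the number greatly. The sulfamide entering in compound 4 is an open-chain group with two donors and two acceptors, closer in kind to the groups of compound 1 and compound 3 than to that of compound 2, so the expected step of a 1.3-fold lower number from compound 3 to compound 4 (0.12 log units; within the scatter) is small, likely within the scatter, with a slight lean toward a lower number. Compound 4 is therefore estimated at 30 nM, in a range from 8 nM to 120 nM.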

Compound 4, inhibition constant: 0.126 nM
Compound 4: middle estimate off by 240-fold (2.38 log units), on the high side; the whole stated range lies above it.
By their numbers in this assay, from the lowest: compounds 2 and 4 (each within the scatter of the next); then compounds 1 and 3 (each within the scatter of the next).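

In this assay the step of a 320-fold lower number from compound 3 to compound 4 (2.50 log units; beyond the scatter) shows that this position sharply separates two open-chain groups of 5 heavy atoms each, carbamoyl(methyl)amino and sulfamoylamino, so the heavy-atom count and the lack of a ring do not settle the number here. A ring is not needed for a very low number either: the step of a 1.3-fold higher number from compound 2 to compound 4 (0.10 log units; within the scatter) lies within the scatter, which places the open-chain group of compound 4 level with the ring-bearing group of compound 2. Sulfur and two oxygens in the group are not enough on their own, as the group of compound 1 also holds them and the step of a 250-fold lower number from compound 1 to compound 4 (2.40 log units; beyond the scatter) is large.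

The change swaps a carbonyl for a sulfonyl and also removes a methyl, and carbamoylamino (the urea without the methyl) and methyl(sulfamoyl)amino (the sulfamide with it) are absent from the compounds shown, so which part of the change carries the step stays open; nothing shown here offers any measurement that would explain the size of the step.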